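This account rests on a few compounds, and the source may have more. Where it says the series, first, only, none or still open, it means among the compounds named here.

In an ADME assay on BJ cells (Homo sapiens) for antiproliferative activity, with a stated time of 72 h (a higher number here means that more compound is needed for the effect, a lower number that less compound is needed), compound 1 `COc1ccc(-c2cc(=O)c3c(OC)cc(OC)cc3n2Cc2ccccc2)cc1` gives > 34400 nM, which is a limit of the assay rather than a measured number. Compound 2 `COC(=O)c1cc(=O)c2c(OC)cc(OC)cc2[nH]1` reaches only a limit in this assay as well, with > 34400 nM. Compound 3 `COc1ccc(-c2cc(=O)c3c(OC)cc(OC)cc3n2S(=O)(=O)c2cccc([N+](=O)[O-])c2)cc1` in this assay likewise gives only a limit, > 39600 nM. Compound 3 therefore stands where all three measured compounds stand, at a limit and not at a number, as described by the limit of > 34400 nM in this assay, at which 2 of the 3 values shown sit, and (the limit of > 39600 nM in this assay, at which 1 of the 3 values shown sits). For the measured compounds named here, no step between two measured compounds can be counted from these values, and no direction emerges from them.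

Compound 4 `COc1ccc(-c2cc(=O)c3c(OC)cc(OC)cc3n2S(=O)(=O)c2cc(Cl)cc(Cl)c2O)cc1` differs from compound 3 in one place: 3,5-dichloro-2-hydroxyphenyl in place of 3-nitrophenyl on a sulfonyl sulfur. With every measured value sitting at a limit, nothing in the data points to a gain or a loss from this change, so the step in this assay is expected to be none beyond the scatter, and compound 4 is expected to reach only a limit again. The estimate for compound 4 in this assay is 40000 nM, with a range from 10000 nM to 120000 nM. The expected step is a step that the limit leaves unreadable from compound 3 to compound 4.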

Compound 4, half-maximal effective concentration: > 37900 nM
Compound 4 was reported as a limit (the forecaster's own chance of this, stated with the estimate: 80%); the middle value is on the limit's open side.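

Compound 3 and compound 4 both stand only at a limit in this assay, and no step can be read between them. The compounds shown leave open whether any change on the sulfonyl sulfur would give a measured number rather than a limit in this assay.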